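Amide substituent change at the chain end of compound 3

The compounds below may be only part of what the source reports. "The series", "measured", "known", "first", "only" and "open" are said of these compounds alone.

Compound 1 `Nc1c(C(=O)NCc2ccc(F)cc2F)c(=O)n(O)c2ncc(CCCCCCOCc3ccccc3)cc12` gives 14400 nM in an ADME assay on HOS cells (Homo sapiens) for cytotoxicity, read by luminescence and ATP content, with a stated time of 48 h; on this read-out higher numbers stand for lower toxicity in this test and lower numbers for higher toxicity in this test. Compound 2 `Nc1c(C(=O)NCc2ccc(F)cc2F)c(=O)n(O)c2ncc(CCCC3CCCCC3)cc12` gives 27400 nM in this assay, and the step of a 1.9-fold higher number from compound 1 to compound 2 (0.28 log units; within the scatter). Compound 3 `CN(C)C(=O)CCc1cnc2c(c1)c(N)c(C(=O)NCc1ccc(F)cc1F)c(=O)n2O` returns only a limit in this assay, > 250000 nM, which is the limit (the limit of > 250000 nM in this assay, at which 1 of the 3 values shown sits), so compound 3 stands at the top of the numbers shown without a number of its own. The steps of an at least 17-fold higher number from compound 1 to compound 3 (1.23 log units; beyond the scatter) and an at least 9.1-fold higher number from compound 2 to compound 3 (0.96 log units; beyond the scatter) both bring in the dimethylcarbamoyl group and both run beyond the scatter. Compound 4 `Nc1c(C(=O)NCc2ccc(F)cc2F)c(=O)n(O)c2ncc(CCC(=O)NCCO)cc12` keeps that carbamoyl and differs from compound 3 only by (2-hydroxyethyl)amino in place of dimethylamino on a carbonyl carbon. Going by the values given here, no measured step alters what sits on the carbonyl carbon, so the expected step of a number no higher from compound 3 to compound 4 (the limit leaves the size open) is none beyond the scatter. Compound 4 is therefore estimated at 250000 nM in this assay, from 120000 nM to 500000 nM, most likely again reported as a limit.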

Compound 4, half-maximal cytotoxic concentration: > 250000 nM
Compound 4 gave a limit, no number (the forecaster's own chance of this, stated with the estimate: 75%); the middle value sits exactly at the limit.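

In this assay the (2-hydroxyethyl)carbamoyl group gives an at least 9.1-fold higher number from compound 2 to compound 4 (0.96 log units; beyond the scatter) and an at least 17-fold higher number from compound 1 to compound 4 (1.23 log units; beyond the scatter). A rise beyond the scatter is therefore seen with two different carbamoyl groups on the saturated chain carbon, not with dimethylcarbamoyl alone. The step between compound 3 and compound 4 cannot be read, as both compounds return only a limit: the limit of > 250000 nM in this assay, at which 2 of the 4 values shown sit.

Any difference between the two carbamoyl groups remains hidden at this limit. On these data alone, how a carboxylic acid or a primary amine at the chain end would read also remains open.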